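This account rests on a few compounds, and the source may have more. Where it says the series, first, only, none or still open, it means among the compounds named here.

Measured compounds:
compound 1, `CCCCCOc1nc(N)c2nc(O)n(Cc3ccccc3)c2n1`: in a functional assay (spleen, spleen) for activation, with Mus musculus as the target (on this read-out higher numbers stand for an effect only at larger amounts of compound and lower numbers for an effect already at smaller amounts), compound 1 gives 0.01 uM
compound 2, `Cc1ccc(Cn2c(O)nc3c(N)ncnc32)cc1`: in this assay compound 2 gives 10 uM
compound 3, `CCCCc1nc(N)c2nc(O)n(Cc3ccccc3)c2n1`: in this assay compound 3 gives 0.03 uM

Compound 1 holds the lowest number of the three in this assay. Nearest to it stands compound 3, reached by a 3.0-fold higher number from compound 1 to compound 3 (0.48 log units; beyond the scatter), butyl in place of pentyloxy on an aromatic carbon. Furthest stands compound 2, which carries no such chain and whose number lies a long way above that of compound 1; no single-point step links the two.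

Compound 4, `COc1nc(N)c2nc(O)n(Cc3ccccc3)c2n1`, is not yet measured. It differs from compound 1 in one place: hydrogen in place of butyl on a saturated chain carbon bound to an oxygen on an aromatic ring. Going by the values given here, the only measured step that bears on this is a 3.0-fold higher number from compound 1 to compound 3 (0.48 log units; beyond the scatter), where a chain of roughly the same length replaced the pentyloxy group and the number rose only modestly. The change to compound 4 is deeper: the oxygen stays, but the chain shrinks to a single carbon. The two values of compound 1 and compound 2 show how far the number can climb once such a chain is missing, though compound 2 differs elsewhere as well. A rise clearly larger than the step to compound 3, yet short of compound 2, is therefore expected. Compound 4 is estimated at 1 uM, in the range 0.2 uM to 5 uM. The expected step is a 100-fold higher number from compound 1 to compound 4 (2.00 log units; beyond the scatter).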

Compound 4, minimum effective concentration: 0.1 uM
Estimate against measurement, compound 4: 10-fold (1.00 log units) above; the whole stated range lies above it.
By their numbers in this assay, from the lowest: compound 1; then compound 3; then compound 4; then compound 2.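

In this assay the chain on the oxygen matters, but shortening it does not abolish the effect: pentyloxy to methoxy gives a 10-fold higher number from compound 1 to compound 4 (1.00 log units; beyond the scatter), and compound 4 still responds at 0.1 uM. The comparison with the butyl group adds a second point, with a 3.3-fold higher number from compound 3 to compound 4 (0.52 log units; beyond the scatter), so on this aromatic carbon the longer chain without the oxygen gives a lower number than the methoxy group with it, and the oxygen alone does not make up for the lost chain length. Nothing among the available data explains either step, so they stand only as observed differences in the read-out.

Three chains do not establish how the number changes with length, and ethoxy, propoxy or a longer chain such as hexyloxy would show whether it falls steadily towards pentyloxy or levels off. Also open, from the compounds shown here alone, is how a butylamino group on the same aromatic carbon would compare with the butyl group of compound 3 and the pentyloxy group of compound 1.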